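Aryl Ether in Place of Furan on the Acylguanidine Core

The source may report more compounds than this note shows. Statements on the series, on what has been measured and on what is new or still open speak of the compounds shown alone.

compound 1, `CCc1cc(Br)c(S(C)(=O)=O)cc1C(=O)N=C(N)N`: 41 nM
compound 2, `Cc1c(C(=O)N=C(N)N)cc(S(C)(=O)=O)c(Cl)c1C`: 58 nM
compound 3, `Cc1cc(-c2ccco2)c(S(C)(=O)=O)cc1C(=O)N=C(N)N`: 16 nM

In a functional assay for inhibition of sodium/hydrogen exchanger (Oryctolagus cuniculus) (a higher number here means a weaker inhibitor, a lower number a stronger inhibitor), compound 3 gives the lowest number of the three; compound 1 stands nearest, beyond the scatter above it, and compound 2 further still, so compound 3 is the strongest inhibitor measured so far. Compound 4, `Cc1cc(Oc2ccccc2Cl)c(S(C)(=O)=O)cc1C(=O)N=C(N)N`, differs from compound 3 in one place: 2-chlorophenoxy in place of furan-2-yl on an aromatic carbon. Among the compounds with values here, no step between measured compounds covers a change of this kind, so the expectation rests on compound 3 alone. The step of a 1.9-fold higher number from compound 3 to compound 4 (0.27 log units; within the scatter) is expected to be modest, toward a somewhat higher number, close to the edge of the scatter. Compound 4 is estimated at 30 nM, with a range from 8 nM to 110 nM.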

Compound 4, half-maximal inhibitory concentration: 14 nM
Beside the measured number, compound 4's estimate is 2.1-fold (0.33 log units) above it; the range from low to high includes it.
By their numbers in this assay, from the lowest: compounds 4 and 3 (each within the scatter of the next); then compounds 1 and 2 (each within the scatter of the next).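

On the aromatic carbon ortho to a methylsulfonyl group, this assay tolerates 2-chlorophenoxy in place of furan-2-yl, with a 1.1-fold lower number from compound 3 to compound 4 (0.06 log units; within the scatter). This position therefore accepts a six-membered aromatic ring of carbon only, 8 heavy atoms in all, as well as a five-membered aromatic ring with 5 heavy atoms, without a change that stands out from the scatter. Nothing at hand bears on why these two groups read alike. The compounds shown leave open what the chlorine of 2-chlorophenoxy contributes, and how an amine or a carboxylic acid on this carbon would read.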